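Swapping the hydroxylated ring on the sulfonyl sulfur

A few compounds are considered here, and "the series" means these few. Any claim that something is new, unique, unknown or untested is made for them only; others in the source may bear on it.

Of the compounds shown here, three sharing one core have been tested in an ADME assay on HepG2 2.2.15 cells (Homo sapiens) for cytotoxicity, read by luminescence, with a stated time of 3 days; a higher number here means that more compound is tolerated, a lower number that less compound is tolerated. Compound 1 `O=C(Nc1ccc(F)c(Cl)c1)c1ccc(F)c(S(=O)(=O)N2CCOC[C@H](O)C2)c1` gives 19000 nM, compound 2 `O=C(Nc1ccc(F)c(Cl)c1)c1ccc(F)c(S(=O)(=O)N2CCCCC(CO)C2)c1` gives 3100 nM, and compound 3 `CC1(O)CCCN(S(=O)(=O)c2cc(C(=O)Nc3ccc(F)c(Cl)c3)ccc2F)CC1` gives 11000 nM. Compound 3 stands second highest of the three numbers: its value lies within the scatter of compound 1, while the gap to compound 2 is beyond the scatter, as a 3.5-fold higher number from compound 2 to compound 3 (0.55 log units; beyond the scatter) shows; compound 2 also sits lowest through a 6.1-fold lower number from compound 1 to compound 2 (0.79 log units; beyond the scatter). Compound 4 `CC(O)C1CCCCN(S(=O)(=O)c2cc(C(=O)Nc3ccc(F)c(Cl)c3)ccc2F)C1` carries 3-(1-hydroxyethyl)azepan-1-yl in place of 4-hydroxy-4-methylazepan-1-yl on a sulfonyl sulfur. Since the entering group resembles the group of compound 2 rather than that of compound 3, the step is expected to run opposite to a 3.5-fold higher number from compound 2 to compound 3 (0.55 log units; beyond the scatter), toward a modestly lower number. Compound 4 is therefore expected to give 4500 nM, within 1500 nM to 13000 nM, an expected step of a 2.4-fold lower number from compound 3 to compound 4 (0.39 log units; beyond the scatter).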

Compound 4, half-maximal cytotoxic concentration: 2600 nM
The estimate for compound 4 lay 1.7-fold (0.24 log units) above the measured number; measured number inside the range.
By their numbers in this assay, from the lowest: compounds 4 and 2 (each within the scatter of the next); then compounds 3 and 1 (each within the scatter of the next).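

In this assay, the 3-(1-hydroxyethyl)azepan-1-yl group gives a 4.2-fold lower number from compound 3 to compound 4 (0.63 log units; beyond the scatter) and a 7.3-fold lower number from compound 1 to compound 4 (0.86 log units; beyond the scatter), so compound 2 is no longer the only low case: both rings with the hydroxyl on a side chain sit below both rings with it on the ring itself. A methyl on the chain carbon bound to the oxygen makes no readable difference, with a 1.2-fold lower number from compound 2 to compound 4 (0.08 log units; within the scatter). On these data alone, whether an amine or a carboxylic acid in place of that hydroxyl, or a longer chain, would follow the same pattern stays open. No measurement shown here explains the pattern.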